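The source may report more compounds than this note shows. Statements on the series, on what has been measured and on what is new or still open speak of the compounds shown alone.

Working notes on the series. Three compounds have numbers in an ADME assay on HepG2 cells (Homo sapiens) for cytotoxicity, read by luminescence, CellTiter-Glo and ATP content, with a stated time of 72 h; on this read-out lower numbers stand for an effect already at smaller amounts and higher numbers for an effect only at larger amounts of compound. Compound 1 `COc1cccc(CNCCCNc2ccnc3cc(C4CCCCC4)ccc23)c1O` gives 1080 nM. Compound 3 `COc1ccc(F)cc1CNCCCNc1ccnc2cc(Cc3ccc(F)cc3Cl)ccc12` gives 2460 nM. Compound 2 `Fc1ccc(-c2ccc3c(NCCCNCc4ccco4)ccnc3c2)cc1` gives 7760 nM, the highest of the three; its nearest neighbour is compound 3, a gap beyond the scatter, and compound 1 lies furthest from it, also beyond the scatter. No pair among these three differs in a single place, so no step within the measured set can be read directly.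

Compound 4 `CCC(CC)c1ccc2c(NCCCNCc3ccco3)ccnc2c1` has not yet been measured in this assay. It differs from compound 2 as follows: pentan-3-yl in place of 4-fluorophenyl on an aromatic carbon. The rest of the molecule, the furan-bearing chain and the shared core, is kept unchanged.

Nothing in the measured set isolates this change; the other two compounds carry both a different substituent on the core and a different amine portion. The expectation for the step from compound 2 to compound 4 in this assay is therefore a modest move, if any, towards a lower number, with the outcome as likely as not to stay within the scatter. The expected step is a 1.7-fold lower number from compound 2 to compound 4 (0.24 log units; within the scatter). On that basis compound 4 is estimated at 4500 nM, with a range from 1500 nM to 13000 nM.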

Compound 4, half-maximal effective concentration: 6760 nM
For compound 4 the middle estimate is 1.5-fold (0.18 log units) below the measured one, within the range that was stated.
By their numbers in this assay, from the lowest: compound 1; then compound 3; then compounds 4 and 2 (each within the scatter of the next).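

In this assay the series now has its first step that changes one place only (a 1.1-fold lower number from compound 2 to compound 4 (0.06 log units; within the scatter)), with the furan-bearing chain and the shared core held constant. At this aromatic carbon, the 4-fluorophenyl group, with its ring and fluorine, and the open pentan-3-yl group, with no ring and fewer heavy atoms, cannot be told apart on this read-out. On this single pair, neither the aromatic ring nor the fluorine of the substituent is needed for the number to stay within the scatter, and nothing on hand indicates why the two groups give values this close.

Compounds 1 and 3 differ from compound 4 in more than one place, so steps to them cannot be read, and the part played by the amine portion remains unresolved. Going by these compounds, it also remains open whether the same flat response would hold with a primary amine, a carboxylic acid or a longer alkyl chain at this aromatic carbon, or whether pentan-3-yl would behave alike with the amine portion of compound 1 in place of the furan-bearing chain.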